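Pyrimidine anilines: furanyl for pyridinyl on a second core

This account rests on a few compounds, and the source may have more. Where it says the series, first, only, none or still open, it means among the compounds named here.

Measured compounds:
compound 1 `CN(C)c1ccc(Nc2nccc(-c3ccccn3)n2)cc1`, 3300 nM
compound 2 `CN(C)c1ccc(Nc2nccc(-c3ccco3)n2)cc1`, 1900 nM
compound 3 `c1ccc(-c2ccnc(Nc3ccc(-n4ccnc4)cc3)n2)nc1`, 1400 nM

Compound 1 and compound 2 share a core and differ by furan-2-yl in place of pyridin-2-yl on an aromatic carbon. In a functional assay for inhibition, with Homo sapiens as the target (on this read-out higher numbers stand for weaker inhibition and lower numbers for stronger inhibition), this gave a 1.7-fold lower number from compound 1 to compound 2 (0.24 log units; within the scatter). Compound 3 carries a different core; how it differs from compound 1 is 1H-imidazol-1-yl in place of dimethylamino on an aromatic carbon, and that change gave a 2.4-fold lower number from compound 1 to compound 3 (0.37 log units; beyond the scatter).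

Compound 4 `c1coc(-c2ccnc(Nc3ccc(-n4ccnc4)cc3)n2)c1` is not yet measured. It differs from compound 3 by furan-2-yl in place of pyridin-2-yl on an aromatic carbon. The place of this change is described in the same words as for compound 1 and compound 2, so it is taken as the same change, now made on the core of compound 3.

Among the compounds with values here, for compound 4 the expected step is a 1.6-fold lower number from compound 3 to compound 4 (0.19 log units; within the scatter), set beside a 1.7-fold lower number from compound 1 to compound 2 (0.24 log units; within the scatter); this rests on the single earlier instance of the change, which lay within the scatter, and on compound 3 at 1400 nM as the starting point. Compound 4 is estimated at 900 nM in this assay, with a range from 450 nM to 1800 nM expected.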

Compound 4, half-maximal inhibitory concentration: 2200 nM
Beside the measured number, compound 4's estimate is 2.4-fold (0.39 log units) below it; the measured number lies above the stated range.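

In this assay, furan-2-yl in place of pyridin-2-yl gives a 1.6-fold higher number from compound 3 to compound 4 (0.20 log units; within the scatter); taken alone, neither instance of this change stands clear of the scatter, yet the two instances do not match: the same change on two cores in this assay, a 1.7-fold lower number (0.24 log units; within the scatter) from compound 1 to compound 2 and a 1.6-fold higher number (0.20 log units; within the scatter) from compound 3 to compound 4, 2.7-fold (0.44 log units) apart, beyond the scatter of two such steps. The companion change, 1H-imidazol-1-yl in place of dimethylamino, gives a 1.2-fold higher number from compound 2 to compound 4 (0.06 log units; within the scatter) and likewise fails to repeat its earlier step: the same change on two cores in this assay, a 2.4-fold lower number (0.37 log units; beyond the scatter) from compound 1 to compound 3 and a 1.2-fold higher number (0.06 log units; within the scatter) from compound 2 to compound 4, 2.7-fold (0.44 log units) apart, beyond the scatter of two such steps. Both comparisons rest on the same four compounds, so they describe a single mismatch seen from two sides: the effect of either change depends on the other group present in this set, but the data do not show why, or whether this extends beyond these compounds.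

Open, going by these compounds, is whether another group at the same place, such as thiophen-2-yl or phenyl, would follow the step on the core of compound 1 or the step on the core of compound 3. Also open, on these data alone, is how an amine such as morpholin-4-yl in place of 1H-imidazol-1-yl would behave with furan-2-yl and with pyridin-2-yl.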